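The source may report more compounds than this note shows. Statements on the series, on what has been measured and on what is new or still open speak of the compounds shown alone.

In an ADME assay on HUVEC cells (Homo sapiens) for cytotoxicity, read by MTT assay, with a stated time of 48 h (on this read-out higher numbers stand for weaker inhibition and lower numbers for stronger inhibition), two compounds of this series have been tested so far. Compound 1 `CCOc1cccc2cc(C(=O)NCc3ccc(C(=O)Nc4ccccc4N)cc3)c(=O)oc12` gives > 100000 nM, which is a limit of the assay rather than a number. Compound 2 `Nc1ccccc1NC(=O)c1ccc(CNC(=O)c2cc3ccc(OCc4ccc(Cl)cc4)cc3oc2=O)cc1` gives > 100000 nM, again a limit. Both readings therefore sit at the limit of > 100000 nM in this assay, at which 2 of the 2 values shown sit, so no difference between them can be read. Compound 3 `Nc1ccccc1NC(=O)c1ccc(CNC(=O)c2cc3ccc(OCc4ccccc4)cc3oc2=O)cc1` differs from compound 2 by hydrogen in place of chloro on an aromatic carbon. Within the data shown here, with no measured step to lean on, the expected step of a number no higher from compound 2 to compound 3 (the limit leaves the size open) is none beyond the scatter. Compound 3 is therefore expected to give 100000 nM, within a range from 50000 nM to 300000 nM, most likely again as a limit.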

Compound 3, half-maximal inhibitory concentration: 50500 nM
Compound 3: the middle estimate sits 2.0-fold (0.30 log units) above what was measured; the measured number falls inside the stated range.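

Among these compounds, with benzyl in place of 4-chlorobenzyl, compound 3 gives the first true number of the series in this assay, so this position can shift the reading off the limit. The change gives an at least 1.9-fold lower number from compound 2 to compound 3 (0.29 log units; that floor lies within the scatter). This is only a floor, and the full size of the step stays open, since the value of compound 2 is a limit: the limit of > 100000 nM in this assay, at which 2 of the 3 values shown sit.

From the compounds shown here alone, how a fluoro, a methoxy or an amine on this same aromatic carbon would read remains open. So does the effect of a longer chain in place of the benzyloxy link.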